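The source may hold more compounds than are shown below. What is called first, only, known or untested is meant among the compounds shown, and "the series" means these compounds.

Working notes on the series. Compound 1 `O=C(/C=C/c1ccc2c(c1)B(O)OC2)c1ccccn1` is the reference point. In an ADME assay on L929 cells (Mus musculus) for cytotoxicity, read by resazurin assay, with a stated time of 72 h (a lower number here means a stronger inhibitor, a higher number a weaker inhibitor), compound 1 gives only a limit, > 10 ug/mL, and no number. Compound 2 `O=C(/C=C/c1ccc2c(c1)B(O)OC2)c1ccc(O)c(O)c1` likewise returns a limit in this assay, > 10 ug/mL. Among the compounds with values here, compound 3 `COc1ccccc1C(=O)/C=C/c1ccc2c(c1)B(O)OC2` is the one member with a number in this assay, 6.35 ug/mL. So compound 1 stands at a limit rather than at a value: the limit of > 10 ug/mL in this assay, at which 2 of the 3 values shown sit, applies to two of the three measurements, and nothing places compound 1 in any order against compound 2, while compound 3 is the only compound that can be set at a point in this assay.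

Compound 4 `O=C(/C=C/c1ccc2c(c1)B(O)OC2)c1ccc(F)cc1` is not yet measured in this assay. It differs from compound 1 in one place: 4-fluorophenyl in place of pyridin-2-yl on a carbonyl carbon. Within the data shown here, no measured pair isolates a change of this kind, so its size cannot be read from the data. In a series where two of three members sit at the limit and the third gives a number, the expected step in this assay is small and without a clear direction beyond the scatter, with a fair chance that compound 4 also comes back as a limit. Compound 4 is estimated at 9 ug/mL, with a range from 4 ug/mL to 20 ug/mL. The expected step is an at least 1.1-fold lower number from compound 1 to compound 4 (0.04 log units; that floor lies within the scatter).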

Compound 4, half-maximal inhibitory concentration: > 10 ug/mL
Compound 4 ended at the assay's limit; the forecaster's own chance of this, stated with the estimate: 55%; middle value at least 1.1-fold (0.04 log units) away from the limit.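

Within the data shown here, compound 1 and compound 4 both stand at a limit in this assay, so no step between them can be read. That limit now covers most of the series: the limit of > 10 ug/mL in this assay, at which 3 of the 4 values shown sit.

The compounds shown leave open how compound 1, compound 2 and compound 4 order against one another in this assay.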